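Adding a Basic Tail to a Limit-Bound Scaffold

The compounds below may be only part of what the source reports. "The series", "measured", "known", "first", "only" and "open" are said of these compounds alone.

compound 1 `Cc1ccc(-c2nnc(-c3ccc(C)c(C(F)(F)F)c3)o2)cc1Nc1nccc(-c2cccnc2)n1`: > 30000 nM
compound 2 `Cc1ccc(-c2nnc(-c3cccnc3)o2)cc1Nc1nccc(-c2cccnc2)n1`: > 30000 nM

In a functional assay on KG-1a cells (Homo sapiens) for inhibition, read by MTT assay, with a stated time of 72 h (on this read-out higher numbers stand for weaker inhibition and lower numbers for stronger inhibition), compound 1 gives > 30000 nM, which is a limit of the assay and not a number. Compound 2 likewise gives > 30000 nM, also a limit. The step that the two limits leave unreadable from compound 1 to compound 2 is therefore unreadable, and both values sit at the limit of > 30000 nM in this assay, at which 2 of the 2 values shown sit. Compound 3 `Cc1ccc(-c2nnc(-c3ccc(CN4CCN(CCN)CC4)c(C(F)(F)F)c3)o2)cc1Nc1nccc(-c2cccnc2)n1` differs from compound 1 by 4-(2-aminoethyl)piperazin-1-yl in place of hydrogen on a saturated chain carbon bound to an aromatic carbon. Within the data shown here, no measured step touches this kind of change, so the expectation rests only on compound 1 standing at the limit. Compound 3 is estimated at 15000 nM, between 2000 nM and 30000 nM. The expected step is an at least 2.0-fold lower number from compound 1 to compound 3 (0.30 log units; that floor lies within the scatter).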

Compound 3, half-maximal inhibitory concentration: 480 nM
For compound 3 the middle estimate is 31-fold (1.49 log units) above the measured one, and the stated range ends above it.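

Placing 4-(2-aminoethyl)piperazin-1-yl on the saturated chain carbon bound to an aromatic carbon gives an at least 62-fold lower number from compound 1 to compound 3 (1.79 log units; beyond the scatter) in this assay. Going by these compounds, this position can therefore move the read-out from a limit to a real number, and the change is large even though its full size stays unknown. The earlier pair could not show this, since its step cannot be read: the limit of > 30000 nM in this assay, at which 2 of the 3 values shown sit.

The compounds shown do not tell which part of the added group matters. A plain piperazine or a morpholine at this position would help separate the ring from the aminoethyl chain.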